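The compounds below may be only part of what the source reports. "The series", "measured", "known", "first", "only" and "open" are said of these compounds alone.

Compound 2, with the structure `Cc1c(OCCCCOc2cccc(C(=O)O)c2)ccc(C(=O)CC(C)C)c1C`, is the starting point of this step. For the measured compounds named here, in an assay on HEK293 cells for positive allosteric modulation of metabotropic glutamate receptor 3 (Rattus norvegicus), read by thallium flux, with a stated time of 2.5 min (on this read-out lower numbers stand for an effect already at smaller amounts and higher numbers for an effect only at larger amounts of compound), compound 2 gives "not determined" (no result reported), so no number fixes where it stands, and the only other measured compound offers no number either. That compound is compound 1, with the structure `Cc1c(OCCCCOc2ccc(C(=O)O)cc2Cl)ccc(C(=O)CC2CCCC2)c1O`, which carries a hydroxy group where compound 2 carries a methyl. In this assay compound 1 gives > 10000 nM, which is a limit of the assay and not a number. The whole picture of measured values therefore rests on (the limit of > 10000 nM in this assay, at which 1 of the 2 values shown sits).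

The unmeasured compound is compound 3, with the structure `Cc1c(OCCCCOc2cccc(C(=O)O)c2)ccc(C(=O)CC(C)C)c1O`. It differs from compound 2 by hydroxy in place of methyl on an aromatic carbon. Going by the values given here, with no measured step of this kind to lean on, the size and direction of the change in this assay are open; the single reading on a closely built compound points toward weak activity rather than a clear gain. Compound 3 is expected to give about 8000 nM, estimated to lie between 1500 nM and 30000 nM, with a real chance that only a limit is reported.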

Compound 3, half-maximal effective concentration: 1430 nM
Compound 3: middle estimate off by 5.6-fold (0.75 log units), on the high side; measured number outside the range, below it.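

In this assay compound 3 gives 1430 nM but no step can be read from it: compound 2 carries no number to set against it, and compound 1 differs from compound 3 in more than one place. On these data alone, what hydroxy in place of methyl does to this read-out stays open. Nothing shown offers a cause for the value of compound 3.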